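The compounds below may be only part of what the source reports. "The series", "measured", "known", "first", "only" and "open" are said of these compounds alone.

Working notes on the series

Compound 1 `CC1C(=O)N(CCCCCCOc2ccc(Cl)cc2)/C(=N\C#N)N1c1ccncc1` gives 303 nM in a functional assay on HONE1 cells for cytotoxicity against HONE1 cell line (Homo sapiens); a lower number here means a stronger inhibitor, a higher number a weaker inhibitor. Compound 2 `CC1C(=O)N(CCCCCCCOc2ccc(Cl)cc2)/C(=N\C#N)N1c1ccncc1` differs from it by (4-chlorophenoxy)methyl in place of 4-chlorophenoxy on a saturated chain carbon, six bonds along the chain from an amide-type nitrogen in a ring, and in this assay compound 2 gives 371 nM, so that a 1.2-fold higher number from compound 1 to compound 2 (0.09 log units; within the scatter). Compound 3 `N#C/N=C1\N(CCCCCOc2ccc(Cl)cc2)C(=O)CCN1c1ccncc1` has a different core; the difference between the two cores is not broken down here. In this assay compound 3 gives 3450 nM, the highest number of the three measured compounds. Compound 4 `N#C/N=C1\N(CCCCCCOc2ccc(Cl)cc2)C(=O)CCN1c1ccncc1` is the not yet measured partner of compound 3, differing by (4-chlorophenoxy)methyl in place of 4-chlorophenoxy on a saturated chain carbon, five bonds along the chain from an amide-type nitrogen in a ring. This is the same kind of change as that from compound 1 to compound 2, though the place differs: five bonds along the chain from the amide-type nitrogen rather than six. Because a 1.2-fold higher number from compound 1 to compound 2 (0.09 log units; within the scatter), compound 4 is expected to land near compound 3, with an estimated step of a 1.2-fold higher number from compound 3 to compound 4 (0.06 log units; within the scatter). The estimate for compound 4 in this assay is 4000 nM, expected between 1800 nM and 9000 nM.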

Compound 4, half-maximal inhibitory concentration: 577 nM
Compound 4: the middle estimate sits 6.9-fold (0.84 log units) above what was measured, outside the stated range (below it).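

The change from 4-chlorophenoxy to (4-chlorophenoxy)methyl now gives a 6.0-fold lower number from compound 3 to compound 4 (0.78 log units; beyond the scatter) in this assay. The size of this step does not carry from one core to the other: the same change on two cores in this assay, a 1.2-fold higher number (0.09 log units; within the scatter) from compound 1 to compound 2 and a 6.0-fold lower number (0.78 log units; beyond the scatter) from compound 3 to compound 4, 7.3-fold (0.86 log units) apart, beyond the scatter of two such steps. The comparison rests on a single pair per core, with the change placed five bonds along the chain on one core and six on the other, so it does not show which feature of the cores, or of the chain, accounts for the gap.

Still open, from the compounds shown here alone, is whether 2-(4-chlorophenoxy)ethyl, a longer chain, would move the number further on either core. Also open, going by these compounds, is how an amine or a carboxylic acid in place of the chlorine would behave.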